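The source may report more compounds than this note shows. Statements on the series, on what has been measured and on what is new or still open speak of the compounds shown alone.

Compound 1 `Cc1nc(-c2ccccc2)c(C(=O)N2CCN(c3cccc(C(F)(F)F)c3)CC2)o1`: 153 nM
Compound 2 `Cc1ccc(C)c(N2CCN(C(=O)c3oc(C)nc3-c3cccc(Cl)c3)CC2)c1`: 345 nM

In a functional assay on HL-60 cells (Homo sapiens) for inhibition, read by MTT assay, with a stated time of 72 h (a higher number here means a weaker inhibitor, a lower number a stronger inhibitor), compound 1 holds the lower of the two numbers measured, and compound 2 lies higher by more than the usual scatter. Compound 3 `CC(=O)Nc1cccc(N2CCN(C(=O)c3oc(C)nc3-c3ccccc3)CC2)c1` is not yet measured. It differs from compound 1 in one place: acetamido in place of trifluoromethyl on an aromatic carbon. Among the measured compounds shown here, no pair of measured compounds covers this change, so nothing measured tells how large its effect is. A modest step toward a higher number is expected, the step of a 2.6-fold higher number from compound 1 to compound 3 (0.42 log units; beyond the scatter) in this assay, with wide uncertainty. Compound 3 is expected to give about 400 nM, with a likely range from 120 nM to 1500 nM.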

Compound 3, half-maximal inhibitory concentration: 329 nM
Compound 3: the middle estimate sits 1.2-fold (0.08 log units) above what was measured, and the stated range covers the measured number.
By their numbers in this assay, from the lowest: compound 1; then compounds 3 and 2 (each within the scatter of the next).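

In this assay the change from 3-(trifluoromethyl)phenyl to 3-acetamidophenyl gives a 2.2-fold higher number from compound 1 to compound 3 (0.33 log units; beyond the scatter) and so shows that this position responds to the swap, though only modestly. The acetamido group brings a hydrogen-bond donor and a hydrogen-bond acceptor that trifluoromethyl lacks, yet inhibition is still seen at a number of the same general order. Nothing measured here gives a reason for this step.

On these data alone, how an amine, a carboxylic acid or a longer chain would behave on this same aromatic carbon remains open. So does whether this step would keep its size on a different core.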